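Dropping the ethoxy group from compound 2

A few compounds are considered here, and "the series" means these few. Any claim that something is new, unique, unknown or untested is made for them only; others in the source may bear on it.

Measured compounds:
compound 1, `Cc1nn(-c2ccccc2F)c2c1C(c1ccc(Oc3ccccc3)cc1)SC(C)C(=O)N2`: 3900 nM
compound 2, `CCOc1cccc(-c2ccc([C@H]3S[C@@H](C)C(=O)Nc4c3c(C)nn4-c3ccccc3C)cc2)c1`: 3500 nM

Among the measured compounds shown here, in an assay on isolated protein for agonist activity at Bile acid receptor (Homo sapiens), read by AlphaScreen, with a stated time of 30 min (a lower number here means that less compound is needed, a higher number that more compound is needed for the effect), compound 2 gives 3500 nM, the lowest of the two numbers so far. Its nearest neighbour is compound 1, which gives 3900 nM; the two numbers lie within the scatter of each other, so they cannot be told apart.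

Compound 3, `Cc1ccccc1-n1nc(C)c2c1NC(=O)[C@H](C)S[C@@H]2c1ccc(-c2ccccc2)cc1`, has not been measured yet. It differs from compound 2 in one place: hydrogen in place of ethoxy on an aromatic carbon. Cut one bond further out, the change reads 3-ethoxyphenyl to phenyl.

For the measured compounds named here, no measured pair in this set shows this change, so there is no direct step to lean on. Since the ethoxy group leaves without anything heavy entering, a modest rise in the number is expected, though a result within the scatter would not surprise. Compound 3 is estimated at 6000 nM, with a likely range of 2000 nM to 18000 nM, which means an expected step of a 1.7-fold higher number from compound 2 to compound 3 (0.23 log units; within the scatter).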

Compound 3, half-maximal effective concentration: 990 nM
Beside the measured number, compound 3's estimate is 6.1-fold (0.78 log units) above it, and the stated range ends above it.
By their numbers in this assay, from the lowest: compound 3; then compounds 2 and 1 (each within the scatter of the next).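

In this assay, putting hydrogen in place of ethoxy on the aromatic carbon gives a 3.5-fold lower number from compound 2 to compound 3 (0.55 log units; beyond the scatter) and so shows that less compound is needed without the ethoxy group. Compounds 1 and 2 could not show this, as they differ in more than one place and their numbers lie within the scatter of each other. For this pair, then, the 3-ethoxyphenyl group is not needed for the effect, and the plain phenyl group does better; nothing available explains why the number falls.

Still open, as far as these compounds go, is what a methoxy group, a fluorine atom, an amine or a carboxylic acid on that same aromatic carbon would do to the number. One step also leaves open whether this change would act the same way with other groups elsewhere on the shared core.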